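Placing a chlorine on the carboxyphenyl end of the chain

A few compounds are considered here, and "the series" means these few. Any claim that something is new, unique, unknown or untested is made for them only; others in the source may bear on it.

Compound 3 `Cc1c(OCCCCOc2cccc(C(=O)O)c2)ccc(C(=O)CC(C)C)c1O` stands lowest of three measured values in an assay on HEK293 cells for positive allosteric modulation of metabotropic glutamate receptor 2 (Rattus norvegicus), read by thallium flux, with a stated time of 2.5 min (on this read-out higher numbers stand for larger maximal responses and lower numbers for smaller maximal responses), giving 84.5%, though compound 1 `Cc1c(OCCCCOc2ccc(C(=O)O)cc2F)ccc(C(=O)CC(C)C)c1O` with 85% and compound 2 `Cc1c(OCCCCOc2ccc(C(=O)O)cc2)ccc(C(=O)CC(C)C)c1O` with 88% lie within the scatter of it. Compound 4 `Cc1c(OCCCCOc2ccc(C(=O)O)c(Cl)c2)ccc(C(=O)CC(C)C)c1O` is the unmeasured partner, and its difference is 4-carboxy-3-chlorophenyl in place of 3-carboxyphenyl on an oxygen on a saturated carbon. Within the data shown here, two measured steps bear on this change: moving the carboxylic acid around the ring gave a number 3.5 percentage points lower from compound 2 to compound 3 (within the scatter), and swapping a halogen for hydrogen gave a number 3 percentage points higher from compound 1 to compound 2 (within the scatter); the combined step a number 0.5 percentage points lower from compound 1 to compound 3 (within the scatter) was also small. Among the measured compounds shown here, no step so far has moved the maximal response beyond the scatter, so compound 4 is expected to show a number 1.5 percentage points higher from compound 3 to compound 4 (within the scatter), no more than scatter. The estimated value for compound 4 is 86%, between 76% and 96%.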

Compound 4, largest response reached (reported as percent of maximum), in percent of the reference or control that the assay uses: 80.5%
The estimate for compound 4 lay 5.5 percentage points above the measured number, within the range that was stated.
By their numbers in this assay, from the lowest: compounds 4, 3, 1 and 2 (each within the scatter of the next).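

Chloro in place of hydrogen on an aromatic carbon gave a number 7.5 percentage points lower from compound 2 to compound 4 (within the scatter) in this assay, so this ring accepts a chlorine as well as a fluorine without a step beyond the scatter. The same holds against the other two ring groups, with a number 4 percentage points lower from compound 3 to compound 4 (within the scatter) and a number 4.5 percentage points lower from compound 1 to compound 4 (within the scatter). No measurement here offers an explanation for these small differences.

Open, going by these compounds, is whether a larger group on this ring, such as methoxy or trifluoromethyl, would keep the response. Also open, on these data alone, is what an amide in place of the carboxylic acid would do.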